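The source may report more compounds than this note shows. Statements on the series, on what has been measured and on what is new or still open speak of the compounds shown alone.

Measured so far:
Compound 1, `CC(C)(C)C(=O)OCC1(CO)C/C(=C\CCCCCCCCCCCO)C(=O)O1`, gives > 10 ug/mL in a functional assay on HL-60 cells (Homo sapiens) for antiproliferative activity (on this read-out lower numbers stand for stronger inhibition of growth and higher numbers for weaker inhibition of growth), which is a limit of the assay rather than a number.
Compound 2, `COCCCCCCCCCCCCCCC/C=C1\CC(CO)(COC(=O)C(C)(C)C)OC1=O`, gives 4.65 ug/mL in this assay.

For the measured compounds named here, compound 2 thus holds the only number in this assay; the other value shown is the limit of > 10 ug/mL in this assay, at which 1 of the 2 values shown sits, so there is no second number to rank it against. Compound 3, `COC(=O)CCCCCCCCCCCCCC/C=C1\CC(CO)(COC(=O)C(C)(C)C)OC1=O`, differs from compound 2 by methoxycarbonyl in place of methoxymethyl on a saturated chain carbon, ten or more bonds along the chain from a double-bonded chain carbon. Going by the values given here, only one measured step touches the same region of the chain: an at least 2.1-fold lower number from compound 1 to compound 2 (0.33 log units; beyond the scatter). That step concerns a different group at the chain end, and it shows that the chain end can move the read-out by a modest amount, but it says nothing directly about a methoxycarbonyl in place of a methoxymethyl. With no closer comparison available, compound 3 is expected to sit near compound 2, and the step of a 1.1-fold higher number from compound 2 to compound 3 (0.03 log units; within the scatter) is estimated to lie within the usual scatter. Compound 3 is therefore estimated at 5 ug/mL, with a range from 2 ug/mL to 12 ug/mL that also allows for a limit instead of a number.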

Compound 3, concentration for 50% growth inhibition: > 10 ug/mL
Compound 3 ended at the assay's limit (the forecaster's own chance of this, stated with the estimate: 25%); at least 2.0-fold (0.30 log units) between middle value and limit.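

In this assay, the new result shows that this chain end does not accept every replacement for methoxymethyl: methoxycarbonyl in place of methoxymethyl gives an at least 2.1-fold higher number from compound 2 to compound 3 (0.33 log units; beyond the scatter). The earlier step had shown only that replacing hydroxy can shift the read-out, whereas here two end groups that each count 0 hydrogen-bond donors still give clearly different results, so the absence of a donor does not by itself preserve the value seen for compound 2. Compound 3 now gives a limit of the assay rather than a number, as compound 1 does, and the step between these two compounds cannot be read: the limit of > 10 ug/mL in this assay, at which 2 of the 3 values shown sit.

For the compounds shown here, compound 2 remains the only compound with a number, so how far compound 3 actually lies from it stays unknown. On these data alone, it also remains open whether a carboxylic acid or an amide at the same chain end, or a longer chain carrying methoxymethyl, would keep a measurable value in this assay.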